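The source may report more compounds than this note shows. Statements on the series, on what has been measured and on what is new or still open speak of the compounds shown alone.

Of the compounds shown here, three have been measured in an assay on HEK293 cells for positive allosteric modulation of metabotropic glutamate receptor 3 (Rattus norvegicus), read by thallium flux, with a stated time of 2.5 min; a higher number here means a larger maximal response, a lower number a smaller maximal response. Compound 1 `Cc1cc(C(=O)O)ccc1OCCCCOc1ccc(C(=O)CC(C)C)c(O)c1C` gives 42.1% in this assay, compound 2 `CCC(=O)c1ccc(OCCCCOc2cc(C(=O)O)ccc2OC)c(C)c1O` gives 62.5% and compound 3 `COc1ccc(C(=O)O)cc1OCCCCOc1ccc(C(=O)C(C)C)c(O)c1C` gives 59.9%. Compound 1 stands lowest of the three, and its distances to compound 3 and to compound 2 both lie beyond the scatter. The difference between the core of compound 1 and the core of compound 3 is not broken down here.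

Compound 3 and compound 2 differ in one place: hydrogen in place of methyl on a saturated chain carbon bound to a carbonyl carbon and a saturated chain carbon. This change produced a number 2.6 percentage points higher from compound 3 to compound 2 (within the scatter).

Compound 4 `CCCC(=O)c1ccc(OCCCCOc2ccc(C(=O)O)cc2C)c(C)c1O` has not yet been measured in this assay. It differs from compound 1 by hydrogen in place of methyl on a saturated chain carbon bound to two saturated chain carbons. For the measured compounds named here, this is the same kind of change as the one from compound 3 to compound 2, but the place is not identical: in the measured pair the carbon bearing the methyl is bound to a carbonyl carbon and a saturated chain carbon, whereas in compound 1 it is bound to two saturated chain carbons. Because the earlier step of a number 2.6 percentage points higher from compound 3 to compound 2 (within the scatter) stayed within the scatter, a step of comparable size, a number 2.9 percentage points higher from compound 1 to compound 4 (within the scatter), is expected here too. Compound 4 is therefore estimated at 45%, between 33% and 58%.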

Compound 4, largest response reached (reported as percent of maximum), in percent of the reference or control that the assay uses: 40.5%
For compound 4 the middle estimate is 4.5 percentage points above the measured one; low and high end bracket the measured number.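

In this assay, going from isobutylcarbonyl to propylcarbonyl gave a number 1.6 percentage points lower from compound 1 to compound 4 (within the scatter). Set beside the earlier step, this means the change reads alike on the two cores: the same change on two cores in this assay, a number 2.6 percentage points higher (within the scatter) from compound 3 to compound 2 and a number 1.6 percentage points lower (within the scatter) from compound 1 to compound 4, 4.2 percentage points apart, within the scatter of two such steps Replacing this methyl with hydrogen therefore moved the maximal response by no more than the scatter on either core, but with only two pairs, this does not establish a rule for other cores, and neither step can show a real effect of the change in either direction.

The compounds shown leave open whether a larger alteration of this side chain, such as a longer chain, a cyclohexyl group or an amine, would move the maximal response beyond the scatter. They also leave open how the series would respond to an amide in place of the carboxylic acid.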